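Turning a Drawn Double Bond from Z to E

A few compounds are considered here, and "the series" means these few. Any claim that something is new, unique, unknown or untested is made for them only; others in the source may bear on it.

Compound 1 `COC(=O)/C=C/NC(=O)[C@@H](O)C(C)(C)CO` and compound 2 `CCOC(=O)/C=C\NC(=O)[C@@H](O)C(C)(C)CO` were both tested in an ADME assay on HEK293 cells (Homo sapiens) for inhibition, read by CellTiter-Glo, with a stated time of 96 h, tested at 100 uM; a lower number here means less inhibition, a higher number more inhibition at the concentration tested (going by the name of the read-out). There compound 1 gives -2%, and compound 2 gives -6%, a number that sits within the usual scatter of the value of compound 1, so the two show no real difference. Among the measured compounds shown here, no step between measured compounds is available here. Compound 3 `CCOC(=O)/C=C/NC(=O)[C@@H](O)C(C)(C)CO` is the next compound; how it differs from compound 2: the two compounds have the same atoms and bonds and differ only in configuration as drawn: 1 of 2 stereo elements differ; a double bond is drawn Z in compound 2 and E in compound 3. With neither earlier compound showing inhibition, the step from compound 2 to compound 3 is expected to be a number 3 percentage points higher from compound 2 to compound 3 (within the scatter), nothing beyond the scatter. Compound 3 is expected to give -3%, within -15% to 10%.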

Compound 3, a percentage reported as inhibition, at one concentration (the size of the read-out at that concentration, not a potency): -9%
For compound 3 the middle estimate is 6 percentage points above the measured one, within the range that was stated.
By their numbers in this assay, from the lowest: compounds 3, 2 and 1 (each within the scatter of the next).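

In this assay redrawing the double bond gives a number 3 percentage points lower from compound 2 to compound 3 (within the scatter) and so shows no real difference between the Z and E forms of this ethyl ester. The comparison rests on one difference alone: the fact that compounds 2 and 3 differ only in the configuration as drawn. With the double bond drawn E in both, methyl in place of hydrogen on a saturated chain carbon bound to an oxygen next to a carbonyl group gives a number 7 percentage points lower from compound 1 to compound 3 (within the scatter) and so shows no real difference either.

On these data alone, whether a carboxylic acid or a longer chain in place of the ester would move the number beyond the scatter stays open.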